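Swapping the tetrazole-bearing ring for a chlorinated sulfonamide ring

This account rests on a few compounds, and the source may have more. Where it says the series, first, only, none or still open, it means among the compounds named here.

Measured compounds:
compound 1 `CCCS(=O)(=O)Nc1ccc(F)c(C(=O)c2n[nH]c3ncc(-c4ccc(C)cc4)cc23)c1F` gives 5.4%
compound 2 `CCCS(=O)(=O)Nc1ccc(F)c(C(=O)c2n[nH]c3ncc(-c4ccc(S(C)(=O)=O)cc4)cc23)c1F` gives 1.5%
compound 3 `CCCS(=O)(=O)Nc1ccc(F)c(C(=O)c2n[nH]c3ncc(-c4ccc(-c5nnn[nH]5)cc4)cc23)c1F` gives 0.15%

These three share one core and differ only in a single group on the outer phenyl ring. In an assay for binding affinity to dual specificity mitogen-activated protein kinase kinase 4 (Homo sapiens), read by KINOMEscan, tested at 100 nM (on this read-out higher numbers stand for a weaker effect at the one concentration tested and lower numbers for a stronger effect), compound 3 gives 0.15%, the smallest of the three numbers, yet the two steps that lead to it are a number 1.4 percentage points lower from compound 2 to compound 3 (within the scatter) and a number 5.3 percentage points lower from compound 1 to compound 3 (within the scatter), both within the scatter, so the three cannot be ranked.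

Compound 4 `CCCS(=O)(=O)Nc1ccc(F)c(C(=O)c2n[nH]c3ncc(-c4ccc(S(N)(=O)=O)cc4Cl)cc23)c1F` is not yet measured. It differs from compound 3 in one place: 2-chloro-4-sulfamoylphenyl in place of 4-(1H-tetrazol-5-yl)phenyl on an aromatic carbon. The three measured steps all exchange groups at this same aromatic carbon, and each stayed within the scatter: a number 3.9 percentage points lower from compound 1 to compound 2 (within the scatter), a number 5.3 percentage points lower from compound 1 to compound 3 (within the scatter) and a number 1.4 percentage points lower from compound 2 to compound 3 (within the scatter). None of them involves a chlorine or a sulfamoyl group, so the change to compound 4 is only loosely covered.

On this basis compound 4 is expected to give 2%, within a range of 0.1% to 10%. The step is estimated as a number 1.9 percentage points higher from compound 3 to compound 4 (within the scatter), which is expected to stay within the scatter.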

Compound 4, a percentage reported as activity, at one concentration (the size of the read-out at that concentration, not a potency): 3.4%
Estimate against measurement, compound 4: 1.4 percentage points below; the range from low to high includes it.
By their numbers in this assay, from the lowest: compounds 3, 2, 4 and 1 (each within the scatter of the next).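

In this assay the outer ring can be changed more heavily than before, with a chlorine and a sulfamoyl group entering together, and the reading still does not move beyond the scatter: the steps are a number 3.3 percentage points higher from compound 3 to compound 4 (within the scatter) and a number 1.9 percentage points higher from compound 2 to compound 4 (within the scatter) and also a number 2 percentage points lower from compound 1 to compound 4 (within the scatter) in this series. So far, then, no group placed at this aromatic carbon separates one compound from another, and the four compounds cannot be ranked. No other data are available to explain this result.

Because the chlorine and the sulfamoyl group arrive together, the compounds shown cannot separate what each one contributes. From the compounds shown here alone, it also remains open whether a carboxylic acid or an amine on the outer ring would shift the reading beyond the scatter.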